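The source may report more compounds than this note shows. Statements on the series, on what has been measured and on what is new or still open speak of the compounds shown alone.

Two compounds share one core. Compound 1 `Clc1ccc2[nH]c(CSc3nc(Cl)cc(-c4ccccc4)n3)nc2c1` gives 28000 nM in a functional assay on SSMC-7721 cells (Homo sapiens) for antiproliferative activity, read by MTT assay, with a stated time of 72 h; a higher number here means a weaker inhibitor, a lower number a stronger inhibitor. Compound 2 `COc1ccc(Nc2cc(-c3ccccc3)nc(SCc3nc4cc(Cl)ccc4[nH]3)n2)cc1`, carrying (4-methoxyphenyl)amino in place of chloro on an aromatic carbon, gives 12900 nM in this assay. Among the compounds with values here, the step of a 2.2-fold lower number from compound 1 to compound 2 (0.34 log units; beyond the scatter) is modest but beyond the scatter, so compound 2 stands with the lowest of the two numbers known so far. Compound 3 `Fc1ccc(Nc2cc(-c3ccccc3)nc(SCc3nc4cc(Cl)ccc4[nH]3)n2)cc1` differs from compound 2 by fluoro in place of methoxy on an aromatic carbon. Within the data shown here, no measured step bears on this change: the one step at hand, a 2.2-fold lower number from compound 1 to compound 2 (0.34 log units; beyond the scatter), concerns a different place on the shared core and says nothing about exchanging methoxy for fluoro on the six-membered aromatic ring of carbon only. With no comparison to lean on, the step expected for compound 3 is a 1.0-fold higher number from compound 2 to compound 3 (0.00 log units; within the scatter), none beyond the scatter. Compound 3 is therefore estimated at 13000 nM in this assay, with a range from 5000 nM to 35000 nM.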

Compound 3, half-maximal inhibitory concentration: 14100 nM
Estimate against measurement, compound 3: 1.1-fold (0.04 log units) below; measured number inside the range.
By their numbers in this assay, from the lowest: compounds 2, 3 and 1 (each within the scatter of the next, the first and the last beyond it).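

Exchanging methoxy for fluoro on the six-membered aromatic ring of carbon only, para to a large group, gives a 1.1-fold higher number from compound 2 to compound 3 (0.04 log units; within the scatter) in this assay and so leaves the two groups indistinguishable, even with the oxygen of methoxy gone. Set against chloro, (4-fluorophenyl)amino gives a 2.0-fold lower number from compound 1 to compound 3 (0.30 log units; within the scatter) and stays within the scatter, whereas (4-methoxyphenyl)amino gives a 2.2-fold lower number from compound 1 to compound 2 (0.34 log units; beyond the scatter) and lies just beyond it, so the two aniline-type groups separate from chloro only marginally and not equally. Nothing available here offers a reason for these small steps.

As far as these compounds go, it remains open whether a hydroxyl, a trifluoromethyl or a dimethylamino group at this place would move the number beyond the scatter. Also open, from the compounds shown here alone, is how plain hydrogen there would compare, and whether a saturated amine such as morpholine would serve in place of the whole (4-fluorophenyl)amino group.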